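A few compounds are considered here, and "the series" means these few. Any claim that something is new, unique, unknown or untested is made for them only; others in the source may bear on it.

Compound 1 `COc1ccccc1C(=O)c1sc(Nc2ccccc2)nc1N` gives 730 nM in a functional assay on CCRF-CEM cells (Homo sapiens) for antiproliferative activity, read by cell counting, with a stated time of 2 days; a lower number here means a stronger inhibitor, a higher number a weaker inhibitor.
Compound 2 `Nc1nc(Nc2ccc(F)cc2)sc1C(=O)c1ccccc1` gives only a limit in this assay, > 10000 nM.
Compound 3 `COc1ccc(C(=O)c2sc(Nc3ccc(F)cc3)nc2N)cc1` likewise gives only a limit in this assay, > 10000 nM.

Compound 1 is the only one of the three with a number; the difference between the cores of compound 1 and compound 2 is not broken down here. From compound 2 to compound 3 the change is methoxy in place of hydrogen on an aromatic carbon, and the resulting step, a step that the two limits leave unreadable from compound 2 to compound 3, cannot be read in size because both ends sit at the limit of > 10000 nM in this assay, at which 2 of the 3 values shown sit. The same change, (methoxy in place of hydrogen on an aromatic carbon), carries compound 1 to compound 4 `COc1ccc(Nc2nc(N)c(C(=O)c3ccccc3OC)s2)cc1`, which has not yet been measured in this assay. Since the measured instance of this change gives no readable size, the expectation for compound 4 rests on the value of compound 1, 730 nM, with a wide margin in either direction. Compound 4 is therefore expected to lie near 1500 nM, between 400 nM and 6000 nM, which means an estimated step of a 2.1-fold higher number from compound 1 to compound 4 (0.31 log units; beyond the scatter).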

Compound 4, half-maximal inhibitory concentration: 17 nM
Beside the measured number, compound 4's estimate is 88-fold (1.95 log units) above it; measured number outside the range, below it.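

On the core of compound 1, in this assay, the change from phenyl to 4-methoxyphenyl gives a large step: a 43-fold lower number from compound 1 to compound 4 (1.63 log units; beyond the scatter). On the other core, the same kind of change cannot be read in size, since compound 2 and compound 3 both sit at a limit of the assay rather than at a number: the limit of > 10000 nM in this assay, at which 2 of the 4 values shown sit. The series therefore shows that methoxy in place of hydrogen on an aromatic carbon can matter greatly on one core, but it does not show that the gain carries from one core to another, and the two instances do not even put the methoxy on the same ring.

Going by these compounds, whether another group in the same place on the core of compound 1, such as an amine, a hydroxyl or a longer chain like ethoxy, would give a step of like size remains open. Also open, on these data alone, is how the methoxy would act on the core of compound 1 at any other place on its rings.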